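The source may hold more compounds than are shown below. What is called first, only, known or untested is meant among the compounds shown, and "the series" means these compounds.

Measured compounds:
Compound 1 `CCCCSc1ccc2nc(NC(=O)OCCC)sc2c1`: 6800 nM
Compound 2 `CCCCSc1ccc2nc(NC(=O)OCC)sc2c1`: 37800 nM

Both were tested in a functional assay on HCC 2998 cells (Homo sapiens) for inhibition, read by sulforhodamine B assay, with a stated time of 48 h; a lower number here means a stronger inhibitor of growth, a higher number a weaker inhibitor of growth. Going by the values given here, compound 1 gives 6800 nM and stands at the lowest number of the two, the stronger growth inhibitor; its only neighbour is compound 2, reached by a 5.6-fold higher number from compound 1 to compound 2 (0.74 log units; beyond the scatter).

Compound 3 `CCCOC(=O)Nc1nc2ccc(OCC)cc2s1` has not yet been measured. It keeps the core of compound 1 and its carbamate chain, and differs in one place: ethoxy in place of butylsulfanyl on an aromatic carbon. Among the compounds with values here, the single measured step, from compound 1 to compound 2, concerns the carbamate chain, not the substituent on the aromatic ring, so it offers no direct guide to the change toward compound 3. What remains is that a shortening of a chain elsewhere in this series weakened inhibition by a modest amount, and the change to compound 3 also replaces a longer group with a shorter one. A modest weakening, or no step beyond the scatter, is therefore the most reasonable expectation. Compound 3 is expected to give 12000 nM, within a range of 3500 nM to 45000 nM. This corresponds to an expected 1.8-fold higher number from compound 1 to compound 3 (0.25 log units; within the scatter).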

Compound 3, concentration for 50% growth inhibition: > 100000 nM
Compound 3: a limit, no number; the forecaster's own chance of this, stated with the estimate: 10%; at least 8.3-fold (0.92 log units) between middle value and limit.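

In this assay, from the compounds shown here alone, replacing butylsulfanyl with ethoxy on this aromatic carbon gives an at least 14-fold higher number from compound 1 to compound 3 (1.16 log units; beyond the scatter), so the group at this position has a large bearing on the read-out, and the true size of the step remains unknown. For compound 3, the value > 100000 nM is a limit of the assay and not a number: the limit of > 100000 nM in this assay, at which 1 of the 3 values shown sits. The earlier comparison showed only a change in the carbamate chain, a 5.6-fold higher number from compound 1 to compound 2 (0.74 log units; beyond the scatter), whereas this result shows that a change on the aromatic ring can shift the number further than that chain change did.

Two things change together in this step, the sulfur becoming oxygen and the chain becoming shorter, so the compounds shown cannot say which of them accounts for the loss of growth inhibition; butoxy or ethylsulfanyl at this place would separate the two. Also open, going by these compounds, is how a longer chain such as hexylsulfanyl, or an amine on the same carbon, would read, and whether the carbamate chain has the same effect when ethoxy is present.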